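Working notes: replacing the methylsulfanyl group of compound 2

This account rests on a few compounds, and the source may have more. Where it says the series, first, only, none or still open, it means among the compounds named here.

Measured so far in a functional assay (Homo sapiens) for inhibition (a lower number here means a stronger inhibitor, a higher number a weaker inhibitor), are two compounds:
- compound 1 (`C[S+]([O-])c1ccc(CSc2nc(-c3ccc(Br)cc3)c(-c3ccncc3)[nH]2)cc1`) gives 820 nM
- compound 2 (`CSc1ccc(CSc2nc(-c3ccccc3)c(-c3ccncc3)[nH]2)cc1`) gives 72500 nM

Compound 2 holds the higher of these two numbers, and its gap to compound 1 lies beyond the scatter, so compound 2 is the weaker inhibitor of the pair. Compound 3 (`C[S+]([O-])c1ccc(CSc2nc(-c3ccccc3)c(-c3ccncc3)[nH]2)cc1`) has yet to be measured in this assay and follows from compound 2 by one change. The methylsulfanyl group leaves (a group of 3 heavy atoms (1 carbon, 1 oxygen, 1 sulfur; no ring) in place of a group of 2 heavy atoms (1 carbon, 1 sulfur; no ring), on an aromatic carbon), on an aromatic carbon of a six-membered aromatic ring of carbon only, para to a large group.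

Going by the values given here, no two measured compounds differ in one place, so this change has no direct precedent. Among the compounds with values here, the entering group also occurs in compound 1 (820 nM), and that is the only guide, a loose one. A drop in the number beyond the scatter is expected in this assay on this basis. The step expected is a 24-fold lower number from compound 2 to compound 3 (1.38 log units; beyond the scatter) and points to a stronger inhibitor. The estimated value for compound 3 is 3000 nM with an expected range from 700 nM to 15000 nM around it.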

Compound 3, half-maximal inhibitory concentration: 840 nM
Compound 3: middle estimate off by 3.6-fold (0.55 log units), on the high side, and the stated range covers the measured number.
By their numbers in this assay, from the lowest: compounds 1 and 3 (each within the scatter of the next); then compound 2.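

In this assay, the place on the aromatic carbon para to a large group proves highly sensitive to this exchange: a group of 3 heavy atoms (1 carbon, 1 oxygen, 1 sulfur; no ring) in place of methylsulfanyl gives an 86-fold lower number from compound 2 to compound 3 (1.94 log units; beyond the scatter) and turns a weak inhibitor into a much stronger one. Hydrogen in place of bromo gives a 1.0-fold higher number from compound 1 to compound 3 (0.01 log units; within the scatter), so with this entering group present, bromo on the other aromatic ring makes no readable difference to inhibition. No measurement at hand explains why the exchange at this place has so large an effect.

The compounds shown do not tell whether this step is specific to the entering group or whether an amine, a carboxylic acid or a longer chain on the same aromatic carbon would give a similar result. They also leave open whether bromo would remain without a readable effect in a compound that keeps the methylsulfanyl group.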